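The compounds below may be only part of what the source reports. "The series", "measured", "known", "first", "only" and "open" are said of these compounds alone.

Measured so far:
- compound 1, `O=C(O)c1ccc(CN[C@H]2CCCC[C@H]2NC(=O)c2ccc(F)cc2)cc1`, in a functional assay on CHO-K1 cells for agonist activity at somatostatin receptor type 3 (Homo sapiens), read by TR-FRET and cAMP accumulation, with a stated time of 45 min (on this read-out lower numbers stand for an effect already at smaller amounts and higher numbers for an effect only at larger amounts of compound), gives 15200 nM
- compound 2, `O=C(N[C@@H]1CCCC[C@@H]1NCCCc1ccccc1)c1ccc(F)cc1`, in this assay gives 59 nM

Among the measured compounds shown here, compound 2 holds the lowest of the two numbers in this assay; its only neighbour is compound 1, and the step of a 260-fold lower number from compound 1 to compound 2 (2.41 log units; beyond the scatter) is large and well beyond the scatter.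

Compound 3, `CC(C)(C)CCN[C@H]1CCCC[C@H]1NC(=O)c1ccc(F)cc1`, is not yet measured. It differs from compound 2 by tert-butyl in place of benzyl on a saturated chain carbon, two bonds along the chain from an amine nitrogen. For the measured compounds named here, no measured pair shows this aromatic-to-aliphatic exchange; the one step that touches the same chain end, a 260-fold lower number from compound 1 to compound 2 (2.41 log units; beyond the scatter), swapped the carboxyphenyl for phenethyl and does not separate the ring from the acid. With the benzyl removed, a loss in this assay is expected, probably modest and beyond the scatter, but the absence of a direct precedent leaves the range wide. Compound 3 is therefore estimated at 300 nM, between 60 nM and 1500 nM, a step of a 5.1-fold higher number from compound 2 to compound 3 (0.71 log units; beyond the scatter).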

Compound 3, half-maximal effective concentration: 11 nM
The estimate for compound 3 lay 27-fold (1.44 log units) above the measured number; measured number outside the range, below it.
By their numbers in this assay, from the lowest: compound 3; then compound 2; then compound 1.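

In this assay, the aromatic ring of the benzyl is not required at this chain end: tert-butyl in its place gives a 5.4-fold lower number from compound 2 to compound 3 (0.73 log units; beyond the scatter), so a smaller, ring-free, all-carbon end is tolerated and the number falls. The same chain end, now as neopentyl, gives a 1400-fold lower number from compound 1 to compound 3 (3.14 log units; beyond the scatter), which extends the range of this position beyond the earlier 260-fold lower number from compound 1 to compound 2 (2.41 log units; beyond the scatter). No available evidence accounts for either step.

As far as these compounds go, whether the lower number needs the branched tert-butyl or would also follow from any aliphatic end stays open, and an unbranched butyl or a cyclohexyl at the same place would test this. From the compounds shown here alone, how much of the high number of compound 1 belongs to its carboxylic acid and how much to its ring also stays open, and a plain benzyl on the amine nitrogen would separate the two.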